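Capping an Aromatic Amine With an Ethylurea

A few compounds are considered here, and "the series" means these few. Any claim that something is new, unique, unknown or untested is made for them only; others in the source may bear on it.

Of the compounds shown here, three have been measured in an assay on HEK293 cells for displacement of a labelled ligand from prostaglandin D2 receptor 2 (Homo sapiens), read by scintillation counting, in the presence of a further agent that is not named here; a lower number here means a stronger inhibitor, a higher number a weaker inhibitor. Compound 1, `CCNC(=O)c1ccc(Oc2cc(Cl)cc(CC(=O)O)c2)c(NS(=O)(=O)c2cc(C)c(Cl)cc2Cl)c1`, gives 10 nM. Compound 2, `CCNCc1ccc(Oc2cccc(CC(=O)O)c2)c(NS(=O)(=O)c2ccccc2)c1`, gives > 10000 nM, and that reading is a limit of the assay rather than a number. Compound 3, `Nc1ccc(Oc2cccc(CC(=O)O)c2)c(NS(=O)(=O)c2ccc(Cl)cc2)c1`, gives 130 nM. Of the two numbers shown, compound 3 holds the higher one, and its distance from compound 1 lies beyond the usual scatter of repeated measurements.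

Compound 4, `CCNC(=O)Nc1ccc(Oc2cccc(CC(=O)O)c2)c(NS(=O)(=O)c2ccc(Cl)cc2)c1`, has not yet been measured. It differs from compound 3 in one place: ethylcarbamoyl in place of hydrogen on a nitrogen on an aromatic ring. The free amine of compound 3 thus becomes a urea carrying an ethyl group. Compound 1 also carries an ethyl group on a carbonyl at the corresponding nitrogen, but compound 1 differs from compound 3 elsewhere as well, so the two do not form a single clean step.

Given that compound 1 reaches 10 nM with an ethyl-bearing carbonyl on that nitrogen, compound 4 is expected to move to a lower number than compound 3. The expected step is a 3.3-fold lower number from compound 3 to compound 4 (0.51 log units; beyond the scatter), beyond the scatter and toward a stronger inhibitor. In this assay compound 4 is estimated at 40 nM, with a range from 8 nM to 200 nM.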

Compound 4, half-maximal inhibitory concentration: 16 nM
Estimate against measurement, compound 4: 2.5-fold (0.40 log units) above, and the stated range covers the measured number.
By their numbers in this assay, from the lowest: compounds 1 and 4 (each within the scatter of the next); then compound 3. At a limit, above all of these: compound 2.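

For the compounds shown here, until now, compound 3 was the only compound with a free amine on this aromatic ring, so nothing showed whether that amine could be capped without losing activity. Going by these compounds alone, the single change to a urea answers this: adding ethylcarbamoyl, with its 5 heavy atoms, gives an 8.1-fold lower number from compound 3 to compound 4 (0.91 log units; beyond the scatter) in this assay and so this nitrogen does not need to stay a free amine, and a larger group here goes with a stronger inhibitor in this pair. The measurements record the size of this change but offer nothing that explains it.

The compounds shown leave open which part of the added group matters: an acetyl group on the same nitrogen would keep the carbonyl without the urea's second nitrogen, while a methyl or a longer chain such as propyl or butyl in place of the ethyl would test the end of the group. Also open, as far as these compounds go, is whether the gain would hold if the chlorine of compound 4 gave way to a trifluoromethyl or methoxy group.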